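A second trifluoromethyl on the outer aryl of compound 1

The source may report more compounds than this note shows. Statements on the series, on what has been measured and on what is new or still open speak of the compounds shown alone.

Compound 1 `COc1cc(Cl)cc(-c2nn(-c3cccc(NC(=O)Nc4cccc(C(F)(F)F)c4)c3)cc2-c2ccncc2)c1` holds the higher of the two numbers in a functional assay on SN12C cells (Homo sapiens) for inhibition, read by sulforhodamine B assay, with a stated time of 48 h, tested at 1 uM (on this read-out lower numbers stand for a stronger effect and higher numbers for a weaker effect at the one concentration tested), giving 59%, while compound 2 `COc1cc(Cl)cc(-c2nn(-c3cccc(NC(=O)c4cccc(C(F)(F)F)c4)c3)cc2-c2ccncc2)c1` gives 58%; the step of a number 1 percentage points lower from compound 1 to compound 2 (within the scatter) lies within the scatter. Compound 3 `COc1cc(Cl)cc(-c2nn(-c3cccc(NC(=O)Nc4cc(C(F)(F)F)cc(C(F)(F)F)c4)c3)cc2-c2ccncc2)c1` differs from compound 1 by trifluoromethyl in place of hydrogen on an aromatic carbon. Among the measured compounds shown here, no measured step touches that part of the structure; the one known step, 3-(trifluoromethyl)phenyl in place of (3-(trifluoromethyl)phenyl)amino on a carbonyl carbon, left the read-out essentially unchanged. A step of no more than the scatter is therefore expected in this assay, at most a slight lean toward a lower number, which is a number 4 percentage points lower from compound 1 to compound 3 (within the scatter). Compound 3 is estimated at 55%, with a range of 40% to 70%.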

Compound 3, a percentage reported as activity, at one concentration (the size of the read-out at that concentration, not a potency): 17%
Compound 3: middle estimate off by 38 percentage points, on the high side; measured number below the stated range.
By their numbers in this assay, from the lowest: compound 3; then compounds 2 and 1 (each within the scatter of the next).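

Among the compounds shown here, on this assay the outer aryl gives the first step beyond the scatter: trifluoromethyl in place of hydrogen on an aromatic carbon gives a number 42 percentage points lower from compound 1 to compound 3 (beyond the scatter) at a place no earlier step had touched. This position therefore responds strongly to substitution, unlike the change on the carbonyl carbon. No measurement at hand bears on the cause.

Open, going by these compounds, is whether a chlorine, a methyl or a methoxy on that same carbon would give a step of similar size. Also open, on these data alone, is whether the second trifluoromethyl would have the same effect on the outer aryl of compound 2.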